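The source may hold more compounds than are shown below. What is called first, only, known or untested is meant among the compounds shown, and "the series" means these compounds.

Measured compounds:
- compound 1, `COc1cc2c(/C=C3/C(=O)Nc4ccc(O)cc43)c(Cl)n(Cc3cc(OC)c(OC)c(OC)c3)c2cc1C`, giving 1410 nM
- compound 2, `O=C1Nc2ccccc2/C1=C\c1c(Cl)n(Cc2ccccc2)c2ccccc12`, giving 12900 nM

Of the compounds shown here, two from this study have been tested in a functional assay on cells (Cancer cell lines, Homo sapiens) for cytotoxicity, with a stated time of 48 h; on this read-out lower numbers stand for stronger inhibition of growth and higher numbers for weaker inhibition of growth. Compound 1 gives 1410 nM, and compound 2 gives 12900 nM in this assay. Compound 1 thus stands at the lowest of the two numbers; its nearest neighbour is compound 2, whose number is higher by a gap that lies beyond the usual scatter of repeated measurements. The two structures differ in several places at once, so nothing can be said about which change accounts for the gap.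

Compound 3, `COc1cc2c(/C=C3/C(=O)Nc4ccc(Cl)cc43)c(Cl)n(Cc3cc(OC)c(OC)c(OC)c3)c2cc1C`, has not yet been measured. It differs from compound 1 in a single place: chloro in place of hydroxy on an aromatic carbon. Among the measured compounds shown here, no pair of measured compounds differing in one place is available, so there is no earlier step to lean on; the expectation rests on the value of compound 1 alone. The step of a 1.3-fold higher number from compound 1 to compound 3 (0.11 log units; within the scatter) is expected to stay within the scatter, in either direction. For compound 3 the estimate in this assay is 1800 nM, with a range from 600 nM to 5500 nM.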

Compound 3, concentration for 50% growth inhibition: 2090 nM
For compound 3 the middle estimate is 1.2-fold (0.06 log units) below the measured one; low and high end bracket the measured number.
By their numbers in this assay, from the lowest: compounds 1 and 3 (each within the scatter of the next); then compound 2.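

In this assay, among the compounds shown here, chloro in place of hydroxy on this aromatic carbon amounts to a 1.5-fold higher number from compound 1 to compound 3 (0.17 log units; within the scatter), the first step that can be read at a single place. At this position, the two groups cannot be told apart on this read-out, even though hydroxy counts a hydrogen-bond donor and a hydrogen-bond acceptor and chloro counts neither, so a hydroxy here is not required for a number in this range. No measured evidence is available that would explain this result.

From the compounds shown here alone, these two groups alone do not show how much this position tolerates, and it remains open whether an amine or a carboxylic acid on the same aromatic carbon would also stay within the scatter of compound 1 and compound 3 or would move the number beyond it. It also remains open which of the several structural differences separating compound 2 from compound 1 accounts for the gap between them.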